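Cyclohexyl to propyl on an amide across two aryl cores

The source may report more compounds than this note shows. Statements on the series, on what has been measured and on what is new or still open speak of the compounds shown alone.

Of the compounds shown here, three have been tested in a functional assay on HeLa cells (Homo sapiens) for cytotoxicity, read by MTT assay, with a stated time of 24 h; a lower number here means a stronger inhibitor, a higher number a weaker inhibitor. Compound 1 `C=CC1=C(C(=O)NCCC)C(c2ccc(F)cc2)OC1` carries a propyl group on its amide nitrogen and a fluorophenyl group on the core. In this assay compound 1 gives > 100000 nM, which is a limit of the assay and not a number. Compound 3 `C=CC1=C(C(=O)NC2CCCCC2)C(c2ccc(F)cc2)OC1` has the same core with a cyclohexyl group on the amide nitrogen. In this assay compound 3 gives > 100000 nM, again a limit and not a number. The change from compound 3 to compound 1 is propyl in place of cyclohexyl on an amide-type nitrogen, and its size is a step that the two limits leave unreadable from compound 3 to compound 1, because the limit of > 100000 nM in this assay, at which 2 of the 3 values shown sit, leaves both ends unreadable.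

Compound 2 `C=CC1=C(C(=O)NC2CCCCC2)C(c2ccc(OC)c(OC)c2)OC1` keeps the cyclohexyl amide but carries a dimethoxyphenyl group on its core; how this core differs from that of compound 3 is not broken down here. In this assay, among the compounds with values here, compound 2 gives 5540 nM, the only number among the three.

Compound 4 `C=CC1=C(C(=O)NCCC)C(c2ccc(OC)c(OC)c2)OC1` has not yet been measured. It differs from compound 2 by propyl in place of cyclohexyl on an amide-type nitrogen, the same kind of change as from compound 3 to compound 1. Since compound 3 and compound 1 both sit at the limit, the measured pair gives no size for this change. Because compound 2 gives 5540 nM, compound 4 is expected to give about 20000 nM, somewhere between 4000 nM and 100000 nM. Within the data shown here, this estimate means a step of a 3.6-fold higher number from compound 2 to compound 4 (0.56 log units; beyond the scatter) and rests only on the single number available, with a real chance that compound 4 also returns a limit.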

Compound 4, half-maximal inhibitory concentration: > 100000 nM
Compound 4: no number, only a limit; the forecaster's own chance of this, stated with the estimate: 45%; middle value at least 5.0-fold (0.69 log units) from the limit.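

Propyl in place of cyclohexyl on an amide-type nitrogen, with the dimethoxyphenyl group on the core, gives in this assay an at least 18-fold higher number from compound 2 to compound 4 (1.25 log units; beyond the scatter), a large loss of activity in this pair. Compound 4 gives > 100000 nM, which is a limit of the assay and not a number, so the true step could be larger than the one printed, and only its smallest possible size is known. The result does not show that the change carries over from one core to another with the same size, since the same change with the fluorophenyl group on the core cannot be read, and the pair with the dimethoxyphenyl group is the only one that gives any size, because both ends of the other pair sit at the limit: the limit of > 100000 nM in this assay, at which 3 of the 4 values shown sit.

With only cyclohexyl and propyl on this nitrogen, the compounds shown leave open whether the ring itself matters or simply the size of the group, which a cyclopentyl ring or a longer chain such as hexyl on the same nitrogen could begin to separate. They also leave open how a chain ending in an amine or a carboxylic acid would behave at this place on either core.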